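This account rests on a few compounds, and the source may have more. Where it says the series, first, only, none or still open, it means among the compounds named here.

Compound 1 `COc1ccc(Br)cc1C(C)NC(=O)N(C)S(=O)(=O)c1ccc(C)cc1`: 12800 nM
Compound 2 `COc1ccc(Cl)cc1C(C)NC(=O)N(C)S(=O)(=O)c1ccccc1`: 1700 nM
Compound 3 `CCOc1ccc(Br)cc1C(C)NC(=O)N(C)S(=O)(=O)c1ccccc1`: 8400 nM

In a functional assay on trachea (Rattus norvegicus, strain Wistar), with a stated time of 15 min (on this read-out higher numbers stand for an effect only at larger amounts of compound and lower numbers for an effect already at smaller amounts), compound 3 lies within the usual scatter of compound 1, while its number is higher than that of compound 2 by a margin beyond the scatter. Compound 4 `COc1ccc(Br)cc1C(C)NC(=O)N(C)S(=O)(=O)c1ccccc1` is reached from compound 3 by one change, hydrogen in place of methyl on a saturated chain carbon bound to an oxygen on an aromatic ring, which turns ethoxy to methoxy. Going by the values given here, no measured pair shows this change alone, so no shift beyond the scatter is expected in this assay. The expected result is a small fall, a 1.7-fold lower number from compound 3 to compound 4 (0.23 log units; within the scatter). The estimated value for compound 4 is 5000 nM, with an expected range from 1800 nM to 13000 nM.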

Compound 4, half-maximal effective concentration: 8400 nM
For compound 4 the middle estimate is 1.7-fold (0.23 log units) below the measured one, within the range that was stated.
By their numbers in this assay, from the lowest: compound 2; then compounds 3, 4 and 1 (each within the scatter of the next).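

Read alone for the first time in this assay, ethoxy to methoxy gives no change at the digits printed from compound 3 to compound 4 (within the scatter) and so leaves this read-out unmoved at this position. Bromo in place of chloro on an aromatic carbon gives a 4.9-fold higher number from compound 2 to compound 4 (0.69 log units; beyond the scatter) and is the only step here beyond the scatter, while hydrogen in place of methyl on an aromatic carbon gives a 1.5-fold lower number from compound 1 to compound 4 (0.18 log units; within the scatter) and stays within it. Nothing given here explains these steps.

Still open, from the compounds shown here alone, is how a longer chain such as propoxy, or a hydroxyl in place of ethoxy, would read.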